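The source may report more compounds than this note shows. Statements on the series, on what has been measured and on what is new or still open speak of the compounds shown alone.

Three measured compounds share one core and differ only in the aryl group carried on an amide-type nitrogen. Compound 1 `COc1cc(NC(C)CCCNC(=O)NNC(=O)Nc2cc(C(F)(F)F)cc(C(F)(F)F)c2)c2ncccc2c1` gives 16000 nM in a functional assay on SW-620 cells (Homo sapiens) for inhibition, read by MTT assay, with a stated time of 72 h; on this read-out higher numbers stand for weaker inhibition and lower numbers for stronger inhibition. Compound 2 `COc1cc(NC(C)CCCNC(=O)NNC(=O)Nc2cccc(C(F)(F)F)c2)c2ncccc2c1` gives 21000 nM in this assay, and the step of a 1.3-fold higher number from compound 1 to compound 2 (0.12 log units; within the scatter) leaves the two values within the scatter of each other, so no order between compound 1 and compound 2 can be read. Compound 3 `COc1cc(NC(C)CCCNC(=O)NNC(=O)Nc2ccc(F)cc2)c2ncccc2c1` reaches only a limit of the assay, > 100000 nM in this assay. Among the two plain numbers, compound 2 holds the higher one, with compound 1 close by.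

The piece now turns to compound 4 `COc1cc(NC(C)CCCNC(=O)NNC(=O)Nc2ccc(Cl)cc2)c2ncccc2c1`, which is not yet measured. It differs from compound 2 as follows: 4-chlorophenyl in place of 3-(trifluoromethyl)phenyl on an amide-type nitrogen. The step that bears most on this change is the exchange of the same 3-(trifluoromethyl)phenyl for 4-fluorophenyl, where an at least 4.7-fold higher number from compound 2 to compound 3 (0.67 log units; beyond the scatter) carried the value to the limit (the limit of > 100000 nM in this assay, at which 1 of the 3 values shown sits). Compound 4 carries 4-chlorophenyl instead, a change of the same kind, so a weakening of similar size is expected, a step of a 3.3-fold higher number from compound 2 to compound 4 (0.52 log units; beyond the scatter). Compound 4 is therefore estimated to give 70000 nM in this assay, with a range from 25000 nM to 200000 nM, and the assay may well report only a limit.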

Compound 4, half-maximal inhibitory concentration: 48000 nM
The estimate for compound 4 lay 1.5-fold (0.16 log units) above the measured number; the range from low to high includes it.
By their numbers in this assay, from the lowest: compounds 1 and 2 (each within the scatter of the next); then compound 4. At a limit, above all of these: compound 3.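

In this assay, the new result shows that replacing 3-(trifluoromethyl)phenyl with a halogen-bearing phenyl on this amide-type nitrogen need not carry the value to the end of the assay: the step of a 2.3-fold higher number from compound 2 to compound 4 (0.36 log units; beyond the scatter) is modest but beyond the scatter, and it ends on a plain number. The identity of the halogen also matters at this place, which compound 3 alone could not show: chloro in place of fluoro on the aromatic carbon gives an at least 2.0-fold lower number from compound 3 to compound 4 (0.31 log units; beyond the scatter) in the direction of stronger inhibition. The size of that step is only a bound, as compound 3 stands at a limit of the assay and not at a number: the limit of > 100000 nM in this assay, at which 1 of the 4 values shown sits.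

The compounds shown leave open how a plain unsubstituted phenyl, or an aryl group carrying a methoxy group, a nitrile or a carboxylic acid, would fall on this nitrogen relative to compound 2 and compound 4. They also leave open whether the order seen here would hold with a longer chain on the shared core, since that chain stays the same in all four compounds.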